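The compounds below may be only part of what the source reports. "The series", "measured", "known", "first", "only" and "open" are said of these compounds alone.

In a functional assay on HO8910 cells (Homo sapiens) for inhibition, read by MTT assay, with a stated time of 24 h, tested at 10 ug/mL (on this read-out higher numbers stand for more inhibition of growth at the one concentration tested and lower numbers for less inhibition of growth), the results so far are these

compound 1 `O=C(O)CCCCC(CCSC(=O)c1ccccc1)SC(=O)c1ccccc1` gives "not active" (no number reported)
compound 2 `O=C(CCCCC1CCSS1)Nc1ccccn1` gives "not active" (no number reported)
compound 3 `O=C(CCCCC1CCSS1)Nc1ccc(Cl)cn1` gives 27.5%

Within the data shown here, compound 3 at 27.5% is the only compound here with a number. Among the measured compounds shown here, compound 1 and compound 2 were reported without one, so no measured step is available for comparison. A single reading at a single concentration also cannot show a trend.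

The next compound to be tested is compound 4 `O=C(CCCCC1CCSS1)Nc1ccc(Br)cn1`, and it differs from compound 3 in one place: bromo in place of chloro on an aromatic carbon. In words, this is bromo in place of chloro on an aromatic carbon of a six-membered aromatic ring with 1 nitrogen.

For the measured compounds named here, with no measured step as a guide, no direction is favoured, and no change beyond the usual scatter of this assay is expected. The expected result is a number 0.5 percentage points higher from compound 3 to compound 4 (within the scatter), a step estimated to be small. This expectation rests on compound 3 at 27.5% alone. Compound 2 was reported as "not active" (no number reported), which leaves some chance that compound 4 also returns no number. If a number is reported, the estimate for compound 4 is 28%, with an expected range from 14% to 42% as the likely span.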

Compound 4, percent growth inhibition at one concentration: 29.6%
Compound 4: the middle estimate sits 1.6 percentage points below what was measured, within the range that was stated.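

In this assay, the exchange of chloro for bromo on this aromatic carbon, two atoms from the ring nitrogen and para to a large group, gives a number 2.1 percentage points higher from compound 3 to compound 4 (within the scatter). Among these compounds, this is the first comparison between two numbers, and it shows that these two halogens can be exchanged at this position without a change beyond the usual scatter, with the rest of the molecule held the same. Nothing measured here bears on why the two compounds read so alike.

Compound 2, which carries neither halogen at this place, gives "not active" (no number reported), so no size can be put on any step from it, and the halogens cannot yet be compared with the unsubstituted ring. From the compounds shown here alone, whether a different kind of group at this position, such as an amine, a methoxy group or a carboxylic acid, would move the reading remains open, as does whether the similarity of compound 3 and compound 4 would hold at other concentrations.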